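A few compounds are considered here, and "the series" means these few. Any claim that something is new, unique, unknown or untested is made for them only; others in the source may bear on it.

Series notes. Compound 1 `CO[C@H]1CC[C@@H](Nc2cc(NCc3cnccc3C(F)(F)F)ncc2C#N)CC1` and compound 2 `N#Cc1cnc(NCc2cnccc2C(F)(F)F)cc1NC1CCOCC1` share the core; in an assay on isolated protein for inhibition of protein kinase C delta type (Homo sapiens), read by TR-FRET, with a stated time of 2 h (on this read-out higher numbers stand for weaker inhibition and lower numbers for stronger inhibition), compound 1 gives 5000 nM, and in this assay compound 2 gives 9800 nM. Going by the values given here, the only measured step, a 2.0-fold higher number from compound 1 to compound 2 (0.29 log units; within the scatter), leaves the two within the scatter of each other, so compound 2 cannot be set apart from compound 1 on these numbers.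

Compound 3 `CNC(=O)[C@H]1CC[C@@H](Nc2cc(NCc3cnccc3C(F)(F)F)ncc2C#N)CC1` differs from compound 2 at the same position: 4-(methylcarbamoyl)cyclohexyl in place of oxan-4-yl on a nitrogen on an aromatic ring. Among the compounds with values here, the one step that bears on this place, a 2.0-fold higher number from compound 1 to compound 2 (0.29 log units; within the scatter), was within the scatter, and no measured pair shows a cyclohexyl carrying a methylcarbamoyl group, so nothing in hand points either way. The expected step of a 1.6-fold lower number from compound 2 to compound 3 (0.21 log units; within the scatter) is therefore none beyond the scatter. For compound 3 the estimate in this assay is 6000 nM, with a range from 1500 nM to 25000 nM.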

Compound 3, half-maximal inhibitory concentration: 1600 nM
Compound 3: the middle estimate sits 3.8-fold (0.57 log units) above what was measured; low and high end bracket the measured number.
By their numbers in this assay, from the lowest: compound 3; then compounds 1 and 2 (each within the scatter of the next).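

In this assay this position, on a nitrogen on an aromatic ring, now shows a step beyond the scatter, which the pair of oxan-4-yl and 4-methoxycyclohexyl did not (a 6.1-fold lower number from compound 2 to compound 3 (0.79 log units; beyond the scatter)). With the cyclohexyl kept, methylcarbamoyl in place of methoxy on a saturated ring carbon also gives a step beyond the scatter (a 3.1-fold lower number from compound 1 to compound 3 (0.49 log units; beyond the scatter)), so the group carried on that ring changes the number and the position is not indifferent to substitution. No measurement at hand gives a reason for either step.

The compounds shown leave open whether the step belongs to the methylcarbamoyl group as a whole or to a part of it; a primary carboxamide, a dimethylcarbamoyl or a carboxylic acid on the same cyclohexyl would bear on that. Also open, as far as these compounds go, is whether a longer chain on the amide nitrogen, or an amine in place of the amide, goes the same way.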